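The source may hold more compounds than are shown below. What is called first, only, known or untested is meant among the compounds shown, and "the series" means these compounds.

Measured compounds:
Compound 1 `Nc1nc(N)c(CCCNc2cc(F)ccc2[N+](=O)[O-])c(O)n1`; > 100000 nM, a limit of the assay.
Compound 2 `Nc1nc(N)c(CCCNc2cc(F)cc(F)c2[N+](=O)[O-])c(O)n1`; 97000 nM.
Compound 3 `Nc1nc(N)c(CCCN(Cc2ccc(NC(CCC(=O)O)C(=O)O)cc2)c2cc(F)cc(F)c2[N+](=O)[O-])c(O)n1`; > 100000 nM, a limit of the assay.

All three compounds were tested in a functional assay on CCRF-CEM cells (Homo sapiens) for cytotoxicity, in the absence of a further agent; a higher number here means a weaker inhibitor, a lower number a stronger inhibitor. Compound 2 gives a number, 97000 nM. For compound 1 only a limit is reported, > 100000 nM. For compound 3 the assay likewise reports only a limit, > 100000 nM. The step from compound 2 to compound 1 is the change (hydrogen in place of fluoro on an aromatic carbon), and it reads an at least 1.0-fold higher number from compound 2 to compound 1 (0.01 log units; that floor lies within the scatter), so the two values cannot be told apart. How compound 3 differs from compound 2 is not broken down here; the two cores differ in more than one place.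

Compound 4 `Nc1nc(N)c(CCCN(Cc2ccc(NC(CCC(=O)O)C(=O)O)cc2)c2cc(F)ccc2[N+](=O)[O-])c(O)n1` is not yet measured in this assay. It stands to compound 3 as compound 1 stands to compound 2: the change is hydrogen in place of fluoro on an aromatic carbon, the same change as before, at the same place. Going by the values given here, the one measured instance of this change gave an at least 1.0-fold higher number from compound 2 to compound 1 (0.01 log units; that floor lies within the scatter), which rests within the scatter, and the starting point, compound 3, already sits at the limit of > 100000 nM in this assay, at which 2 of the 3 values shown sit. The expectation for compound 4 in this assay is therefore a step that the limit leaves unreadable from compound 3 to compound 4 from compound 3, that is, essentially no movement. Compound 4 is expected to give 150000 nM in this assay, most likely again only as a limit, with a plausible range of 70000 nM to 400000 nM.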

Compound 4, half-maximal inhibitory concentration: > 100000 nM
Compound 4: no number, only a limit; the forecaster's own chance of this, stated with the estimate: 85%; the middle value is on the limit's open side.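

In this assay compound 4 gives > 100000 nM, a limit of the assay and not a number. Going by these compounds alone, compound 3 stands at the same limit, so no step between compound 3 and compound 4 can be read. The compounds shown leave open whether the change from 3,5-difluoro-2-nitrophenyl to 5-fluoro-2-nitrophenyl moves the value of this pair at all, and in which direction.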